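Swapping the piperazine of compound 2 for a fused bicyclic amine

This account rests on a few compounds, and the source may have more. Where it says the series, first, only, none or still open, it means among the compounds named here.

Compound 1 `CCc1nc2cc(Cl)ccn2c1C(=O)NCc1ccc(-c2ccncc2)cc1` gives 0.482 h in an ADME assay (liver) for metabolic stability, with Liver microsome (Homo sapiens) as the target, using microsomes; a lower number here means that the compound disappears faster, a higher number that the compound lasts longer. Compound 2 `CCc1nc2cc(Cl)ccn2c1C(=O)NCc1ccc(N2CCN(C(C)C)CC2)cc1` reads > 2 h, which is a limit and not a number. Compound 3 `CCc1nc2cc(Cl)ccn2c1C(=O)NCc1ccc(N2CC3CCCCC3C2)cc1` changes the same aromatic carbon again: a group of 9 heavy atoms (8 carbon, 1 nitrogen; one five-membered non-aromatic ring with 1 hetero atom, one six-membered non-aromatic ring of carbon only) in place of a group of 9 heavy atoms (7 carbon, 2 nitrogen; one six-membered non-aromatic ring with 2 hetero atoms), on an aromatic carbon. Going by the values given here, one measured step bears on this change: an at least 4.1-fold higher number from compound 1 to compound 2 (0.61 log units; beyond the scatter), with 4-isopropylpiperazin-1-yl in place of pyridin-4-yl on an aromatic carbon. Among the compounds with values here, its size is only a bound, and it is the sole step at this place. Compound 3 also carries non-aromatic rings at that carbon, so it is expected to keep part of the gain seen in an at least 4.1-fold higher number from compound 1 to compound 2 (0.61 log units; beyond the scatter), though not necessarily all of it. The expected step is modest and downward in this assay: an at least 1.6-fold lower number from compound 2 to compound 3 (0.22 log units; that floor lies within the scatter). For compound 3 the estimated half-life is 1.2 h, with an expected range of 0.4 h to 3.5 h.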

Compound 3, half-life: 0.248 h
Compound 3: the middle estimate sits 4.8-fold (0.68 log units) above what was measured; the measured number lies below the stated range.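

In this assay, non-aromatic rings at this aromatic carbon are not enough to keep the gain, as the change to the fused group gives an at least 8.0-fold lower number from compound 2 to compound 3 (0.90 log units; beyond the scatter). Set against pyridin-4-yl, the fused group gives a 1.9-fold lower number from compound 1 to compound 3 (0.29 log units; within the scatter), so these two groups cannot be told apart in this read-out. The reading for compound 2 is a limit and not a number, so the first step is only a bound on its size: the limit of > 2 h in this assay, at which 1 of the 3 values shown sits.

The compounds shown do not separate the effect of the second ring nitrogen from that of the fused carbocycle or the isopropyl group. A simple piperidine, a morpholine or a piperazine bearing a methyl group on its nitrogen at this carbon would help to tell these apart.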